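Quinoline ester series: triazolylsulfanyl to ethylimidazolyl swap

This account rests on a few compounds, and the source may have more. Where it says the series, first, only, none or still open, it means among the compounds named here.

Working notes on three measured compounds and one to be tested. In a functional assay on the whole organism for inhibition, with Rattus norvegicus as the target, at a dose of 50 mg/kg by the oral route (on this read-out higher numbers stand for more inhibition at the one dose given (going by the name of the read-out) and lower numbers for less inhibition), compound 1 `CCOC(=O)c1c(CSc2nncn2C)nc2cc(OC)c(OC)cc2c1-c1ccc(OC)c(OC)c1` gives 66%. Compound 2 `CCOC(=O)c1c(CSc2nccn2C)nc2cc(OC)c(OC)cc2c1-c1ccc(C)cc1` gives 67% in this assay, and compound 3 `CCOC(=O)c1c(CSc2nccn2C)nc2cc(OCC)c(OCC)cc2c1-c1ccc(OC)c(OC)c1` gives 59%. Compound 1 thus stands among three numbers that all lie within the usual scatter of one another, so no ordering of the three is read from them. Compound 4 `CCOC(=O)c1c(Cn2ccnc2CC)nc2cc(OC)c(OC)cc2c1-c1ccc(OC)c(OC)c1` differs from compound 1 in one place: 2-ethyl-1H-imidazol-1-yl in place of (4-methyl-4H-1,2,4-triazol-3-yl)sulfanyl on a saturated chain carbon bound to an aromatic carbon. Among the compounds with values here, no measured pair shows this change, so its size is unknown; a modest step, if any, is expected, with a slight lean downward. Compound 4 is expected to give 58% in this assay, with a range from 40% to 75%, which means an expected step of a number 8 percentage points lower from compound 1 to compound 4 (within the scatter).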

Compound 4, a percentage reported as inhibition, in the whole organism at one dose (the size of the read-out at that dose, not a potency): 65%
Compound 4: middle estimate off by 7 percentage points, on the low side; measured number inside the range.
By their numbers in this assay, from the lowest: compounds 3, 4, 1 and 2 (each within the scatter of the next).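

In this assay, within the data shown here, the change from (4-methyl-4H-1,2,4-triazol-3-yl)sulfanyl to 2-ethyl-1H-imidazol-1-yl on a saturated chain carbon bound to an aromatic carbon gives a number 1 percentage points lower from compound 1 to compound 4 (within the scatter), the first comparison that differs in one place. At this one dose, the read-out does not separate the two groups, although the entering group has no sulfur and fewer hydrogen-bond acceptors. No measured property of either group offers an explanation for this result.

As far as these compounds go, it remains open whether a morpholine ring or a carboxylic acid on this carbon would give a similar number. Also open, from the compounds shown here alone, is whether the same change would give a similar step on the cores of compound 2 or compound 3.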